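Compound 3: one more ethyl on the chain

A few compounds are considered here, and "the series" means these few. Any claim that something is new, unique, unknown or untested is made for them only; others in the source may bear on it.

Measured in an ADME assay on PBMC cells (Homo sapiens) for cytotoxicity; a higher number here means that more compound is tolerated, a lower number that less compound is tolerated:
- Compound 1 `CC(=O)Nc1nc(N)nc2c1ncn2[C@H]1CO[C@@H](CO)O1`: > 100000 nM
- Compound 2 `CCCC(=O)Nc1nc(N)nc2c1ncn2[C@H]1CO[C@@H](CO)O1`: > 100000 nM

Compound 2 stands at > 100000 nM, and this is a limit of the assay, not a number. Compound 1 gives > 100000 nM, which is also a limit. So the data so far hold no exact value, only (the limit of > 100000 nM in this assay, at which 2 of the 2 values shown sit).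

The next structure is compound 3 `CCCCCC(=O)Nc1nc(N)nc2c1ncn2[C@H]1CO[C@@H](CO)O1`, and the change is ethyl in place of hydrogen on a saturated chain carbon, three bonds along the chain from a carbonyl carbon. In words, this is ethyl in place of hydrogen on a saturated chain carbon, three bonds along the chain from a carbonyl carbon.

Among the measured compounds shown here, the one measured step that bears on this is a step that the two limits leave unreadable from compound 1 to compound 2. It made the same kind of swap closer to the carbonyl carbon, but it has no readable size to carry forward. With compound 2 at > 100000 nM, no step beyond the usual scatter is expected, in either direction, and a further limit is the likeliest report. The expected step is a number no higher from compound 2 to compound 3 (the limit leaves the size open).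

For compound 3 the estimated value is 100000 nM, with an expected range from 40000 nM to 150000 nM.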

Compound 3, half-maximal cytotoxic concentration: > 100000 nM
Compound 3 was reported as a limit (the forecaster's own chance of this, stated with the estimate: 75%); the middle value lies on the limit itself.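

In this assay compound 3 gives > 100000 nM, which is a limit of the assay and not a number. No step among compound 1, compound 2 and compound 3 can be read: the limit of > 100000 nM in this assay, at which 3 of the 3 values shown sit.

The compounds shown leave open where the true cytotoxic concentration of each lies, and whether chain length changes it at all.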